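The source may report more compounds than this note shows. Statements on the series, on what has been measured and on what is new or still open speak of the compounds shown alone.

Compound 1 (`Cc1nnsc1CO/N=C/c1c(C)nn(C)c1Oc1ccc(F)cc1`), compound 2 (`Cc1nnsc1CO/N=C/c1c(C)nn(C)c1Oc1ccc(Br)cc1`) and compound 3 (`Cc1nnsc1CO/N=C/c1c(C)nn(C)c1Oc1ccc(I)cc1`) share one core and were read in a functional assay on Huh-7 cells (Homo sapiens) for inhibition, read by MTT assay, with a stated time of 48 h; on this read-out higher numbers stand for weaker inhibition and lower numbers for stronger inhibition. Compound 1 gives > 50000 nM, a limit. Compound 2 gives 11800 nM. Compound 3 gives > 50000 nM, also a limit, so it has no number of its own.

Compound 4 (`Cc1nnsc1CO/N=C/c1c(C)nn(C)c1Oc1ccc(OC(F)(F)F)cc1`) differs from compound 3 by trifluoromethoxy in place of iodo on an aromatic carbon, with trifluoromethoxy in place of iodo on an aromatic carbon, para to a large group.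

Three swaps at this place bear on it: an at least 4.2-fold lower number from compound 1 to compound 2 (0.62 log units; beyond the scatter), an at least 4.2-fold higher number from compound 2 to compound 3 (0.62 log units; beyond the scatter) and a step that the two limits leave unreadable from compound 1 to compound 3. They set no trend, and only compound 2 gives a number, at 11800 nM. A modest move to a lower number is therefore expected at most. The expected step is an at least 1.4-fold lower number from compound 3 to compound 4 (0.15 log units; that floor lies within the scatter). Compound 4 is estimated at 35000 nM, with an expected range from 9000 nM to 90000 nM.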

Compound 4, half-maximal inhibitory concentration: > 50000 nM
Compound 4: only a limit was reported (the forecaster's own chance of this, stated with the estimate: 55%); at least 1.4-fold (0.15 log units) between middle value and limit.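

In this assay compound 4 gives > 50000 nM as a limit. Trifluoromethoxy at this place therefore falls with fluoro and iodo, leaving bromo as the only group here with a measured number, and an at least 4.2-fold higher number from compound 2 to compound 4 (0.62 log units; beyond the scatter) as the one readable new step. The steps from compound 1 and compound 3 to compound 4 cannot be read, and the series is cut off at one value: the limit of > 50000 nM in this assay, at which 3 of the 4 values shown sit.

As far as these compounds go, how compound 1, compound 3 and compound 4 rank among themselves stays open. Also open, from the compounds shown here alone, is whether an amine, a carboxylic acid or a longer chain at this place would give a number.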